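Swapping the furan-2-yl group for a cyclobutyl ring

This account rests on a few compounds, and the source may have more. Where it says the series, first, only, none or still open, it means among the compounds named here.

Of the compounds shown here, three sharing one core have been tested. Compound 1 `Cc1cccc(Cn2c(CN3CCN(C(=O)c4ccc([N+](=O)[O-])cc4)CC3)nc3ccccc32)c1` gives 24.3% in an assay on isolated protein for inhibition of aldehyde dehydrogenase 1A1 (Homo sapiens), read by spectrophotometry, tested at 10 uM; a higher number here means more inhibition at the concentration tested (going by the name of the read-out), a lower number less inhibition; compound 2 `Cc1cccc(Cn2c(CN3CCN(C(=O)c4ccc(C#N)cc4)CC3)nc3ccccc32)c1` gives 20.8%; compound 3 `Cc1cccc(Cn2c(CN3CCN(C(=O)c4ccco4)CC3)nc3ccccc32)c1` gives 73.2% and so stands highest of the three, its steps from compound 1 and compound 2 being a number 48.9 percentage points higher from compound 1 to compound 3 (beyond the scatter) and a number 52.4 percentage points higher from compound 2 to compound 3 (beyond the scatter), while a number 3.5 percentage points lower from compound 1 to compound 2 (within the scatter). Compound 4 `Cc1cccc(Cn2c(CN3CCN(C(=O)C4CCC4)CC3)nc3ccccc32)c1` differs from compound 3 in one place: cyclobutyl in place of furan-2-yl on a carbonyl carbon. Within the data shown here, no measured step involves a cyclobutyl group; the two large steps only show that moving away from either substituted phenyl group toward furan-2-yl raised inhibition strongly. Leaving furan-2-yl again is therefore expected to lower inhibition, by a number 33.2 percentage points lower from compound 3 to compound 4 (beyond the scatter). Compound 4 is estimated at 40%, plausibly between 15% and 70%.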

Compound 4, a percentage reported as inhibition, at one concentration (the size of the read-out at that concentration, not a potency): 69.1%
Beside the measured number, compound 4's estimate is 29.1 percentage points below it; the range from low to high includes it.
By their numbers in this assay, from the lowest: compounds 2 and 1 (each within the scatter of the next); then compounds 4 and 3 (each within the scatter of the next).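

In this assay the aromatic furan-2-yl ring, with its oxygen, can be replaced by the non-aromatic, all-carbon cyclobutyl ring on this carbonyl carbon with no clear change (a number 4.1 percentage points lower from compound 3 to compound 4 (within the scatter)). Cyclobutyl also stands far from both substituted phenyl groups (a number 48.3 percentage points higher from compound 2 to compound 4 (beyond the scatter); a number 44.8 percentage points higher from compound 1 to compound 4 (beyond the scatter)), so an aromatic ring is not needed here for this level of inhibition. Nothing available explains these differences.

Still open, on these data alone, is whether plain phenyl behaves like its substituted forms or like furan-2-yl. Cyclopentyl, an open butyl chain and an amine-bearing ring also remain untested in this account.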